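Swapping bromine for chlorine on a coumarin-pyridazine inhibitor

A few compounds are considered here, and "the series" means these few. Any claim that something is new, unique, unknown or untested is made for them only; others in the source may bear on it.

Of the compounds shown here, three sharing one core have been measured in an assay on cells for inhibition of Amine oxidase [flavin-containing] B (Homo sapiens), read by fluorescence and Amplex Red, with a stated time of 15 min; on this read-out higher numbers stand for weaker inhibition and lower numbers for stronger inhibition. Compound 1 `Cc1ccc2cc(-c3ccc(Br)nn3)c(=O)oc2c1` gives 750 nM in this assay. Compound 2 `COc1ccc2oc(=O)c(-c3ccc(Br)nn3)cc2c1` gives 560 nM, and compound 3 `COc1ccc2cc(-c3ccc(Br)nn3)c(=O)oc2c1` gives 3050 nM. Among these three numbers compound 1 stands second highest; the gap to compound 2 is within the scatter, so the two cannot be ranked, while the gap to compound 3 is beyond it. Going by the values given here, the one single-point step measured is a 4.1-fold higher number from compound 1 to compound 3 (0.61 log units; beyond the scatter), a modest loss in potency.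

Compound 4 `Cc1ccc2cc(-c3ccc(Cl)nn3)c(=O)oc2c1` differs from compound 1 in one place: chloro in place of bromo on an aromatic carbon. Among the compounds with values here, no measured step touches this halogen position; the only step known concerns the methyl-to-methoxy exchange on a different ring, and it says nothing about chloro against bromo. Without any bearing step, the expectation is that exchanging one halogen for another of similar kind at the same place leaves the half-maximal inhibitory concentration close to that of compound 1, with no change beyond the scatter, though a small drift either way cannot be ruled out. The estimate for compound 4 in this assay is therefore 950 nM, with a range from 400 nM to 2300 nM, which corresponds to an expected step of a 1.3-fold higher number from compound 1 to compound 4 (0.10 log units; within the scatter).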

Compound 4, half-maximal inhibitory concentration: 2510 nM
Compound 4: the middle estimate sits 2.6-fold (0.42 log units) below what was measured; measured number outside the range, above it.
By their numbers in this assay, from the lowest: compounds 2 and 1 (each within the scatter of the next); then compounds 4 and 3 (each within the scatter of the next).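

The halogen on the six-membered aromatic ring with 2 nitrogen is not a silent position: in this assay, chloro in place of bromo gives a 3.3-fold higher number from compound 1 to compound 4 (0.52 log units; beyond the scatter). Going by these compounds alone, until now, the only measured step concerned the methyl-to-methoxy exchange elsewhere in the molecule, so the earlier compounds gave no information about this place. This result shows that, on the core of compound 1, bromo goes with stronger inhibition than chloro, and that even an exchange between two halogens can move the number beyond the usual scatter. Nothing available here accounts for this difference between bromo and chloro.

From the compounds shown here alone, this is one matched pair, so it remains open whether the same exchange would produce a step of similar size on the cores of compound 2 and compound 3, which carry a methoxy group. It is also unknown how other groups at this place, such as iodo, a nitrile or an amine, would compare with bromo.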